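One Aryl Group Exchanged, Cytotoxicity Yet to Be Measured

A few compounds are considered here, and "the series" means these few. Any claim that something is new, unique, unknown or untested is made for them only; others in the source may bear on it.

The series shares the core of compound 1 `O=C1CS/C(=N\c2csc(-c3ccc(Cl)cc3)c2)N1`. In a functional assay on MDA-MB-231 cells (Homo sapiens) for cytotoxicity, read by MTT assay, with a stated time of 72 h (a higher number here means a weaker inhibitor, a lower number a stronger inhibitor), compound 1 reaches only the limit of the assay, > 50000 nM; this is a limit and not a number, as noted in the limit of > 50000 nM in this assay, at which 1 of the 2 values shown sits. Compound 2 `Cc1ccc(/C=C2\S/C(=N\c3csc(-c4ccc(Cl)cc4)c3)NC2=O)cc1` carries a 4-methylphenyl group on a double-bonded chain carbon bound to a double-bonded ring carbon, and in this assay compound 2 gives 900 nM. Among the compounds with values here, that is the only number so far; the other value shown is the limit just named, so compound 2 cannot be placed against any other measured compound.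

Compound 3 `COc1ccc(/C=C2\S/C(=N\c3csc(-c4ccc(Cl)cc4)c3)NC2=O)cc1OC` has not been measured. It differs from compound 2 in one place: 3,4-dimethoxyphenyl in place of 4-methylphenyl on a double-bonded chain carbon bound to a double-bonded ring carbon. Within the data shown here, no measured pair shows what such an exchange does, so the expectation rests on compound 2 alone. The step from compound 2 to compound 3 is expected to be a 1.7-fold higher number from compound 2 to compound 3 (0.22 log units; within the scatter), that is, no change beyond the usual scatter or at most a slight weakening. Compound 3 is accordingly estimated at 1500 nM, with a range from 400 nM to 6000 nM.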

Compound 3, half-maximal inhibitory concentration: 1900 nM
For compound 3 the middle estimate is 1.3-fold (0.10 log units) below the measured one, and the stated range covers the measured number.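

Within the data shown here, this is the first pair that differs in one place, so the effect of exchanging the group on a double-bonded chain carbon bound to a double-bonded ring carbon can now be read directly: in this assay, 3,4-dimethoxyphenyl in place of 4-methylphenyl gives a 2.1-fold higher number from compound 2 to compound 3 (0.32 log units; beyond the scatter). Among these compounds, the step is modest but beyond the scatter, so this position is not indifferent to the exchange, although an aryl group of 10 heavy atoms with 2 hydrogen-bond acceptors costs only this modest step. Nothing measured here bears on why the number rises.

On these data alone, it remains open whether the step belongs to the two methoxy groups together, to one of them alone, or to the loss of the methyl group; an unsubstituted phenyl or a phenyl carrying a single methoxy group at this place would begin to separate these readings. Also open, as far as these compounds go, is how the position answers to an aryl group bearing an amine or a carboxylic acid, or to a longer alkyl chain in place of the aryl group.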